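The source may hold more compounds than are shown below. What is called first, only, known or untested is meant among the compounds shown, and "the series" means these compounds.

Measured compounds:
- Compound 1 `Fc1ccccc1Cn1cc(CSC(=S)N2CCNCC2)nn1`: 19400 nM
- Compound 2 `COc1ccc(Cn2cc(CSC(=S)N3CCNCC3)nn2)cc1`: "not determined" (no result reported)
- Compound 3 `S=C(SCc1cn(Cc2ccc(Cl)c(Cl)c2)nn1)N1CCNCC1`: "not determined" (no result reported)

In a functional assay on MGC-803 cells (Homo sapiens) for inhibition, read by MTT assay, with a stated time of 72 h (on this read-out lower numbers stand for stronger inhibition and higher numbers for weaker inhibition), compound 1 gives 19400 nM. For compound 2 the result in this assay is "not determined" (no result reported). Compound 3 stands without a number: in this assay its result is "not determined" (no result reported), so nothing is known of where it lies against compound 1.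

Compound 4 `O=C(OCc1ccccc1)N1CCN(C(=S)SCc2cn(Cc3ccc(Cl)c(Cl)c3)nn2)CC1` is not yet measured. It differs from compound 3 by benzyloxycarbonyl in place of hydrogen on an amine nitrogen in a ring. Going by the values given here, no measured pair shows what this change does, so the size of the step in this assay cannot be drawn from the data, and any direction, or no change beyond the scatter, remains open.

Compound 4 is expected to give about 8000 nM in this assay, within a range from 1500 nM to 40000 nM.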

Compound 4, half-maximal inhibitory concentration: 7140 nM
Estimate against measurement, compound 4: 1.1-fold (0.05 log units) above, and the stated range covers the measured number.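

Going by these compounds alone, compound 3 has no single number in this assay, so no step to compound 4 at 7140 nM can be read. What benzyloxycarbonyl in place of hydrogen does therefore stays open, and nothing shown offers an explanation.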